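The compounds below may be only part of what the source reports. "The series", "measured", "known", "first", "only" and "open" are said of these compounds alone.

Measured so far:
compound 1 `Cc1cc(C(=O)O)nn1Cc1cc(Br)ccc1OCc1ccccc1` with 6.46 nM
compound 2 `Cc1cc(C(=O)O)nn1Cc1cc(Br)ccc1OCc1ccc(Cl)cc1Cl` with 0.132 nM

Both numbers come from an assay on CHO-K1 cells for displacement of a labelled ligand from prostaglandin E2 receptor EP1 subtype (Homo sapiens); a lower number here means a stronger inhibitor, a higher number a weaker inhibitor. Compound 2 stands lowest of the two, and its nearest neighbour is compound 1, which gives 6.46 nM. Compound 3 `Cc1cc(C(=O)O)nn1Cc1cc(Br)ccc1OCc1ccc(F)cc1F` arises from compound 2 through one change: 2,4-difluorophenyl in place of 2,4-dichlorophenyl on a saturated chain carbon bound to an oxygen on an aromatic ring. Among the measured compounds shown here, only one measured step bears on it, a 49-fold lower number from compound 1 to compound 2 (1.69 log units; beyond the scatter), which put a 2,4-dichlorophenyl in place of a plain phenyl. Two fluorines in place of two chlorines are expected to return only part of that gain. The step to compound 3 is expected to be an increase, a 7.6-fold higher number from compound 2 to compound 3 (0.88 log units; beyond the scatter), beyond the scatter. Compound 3 is estimated at 1 nM, within 0.2 nM to 5 nM.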

Compound 3, half-maximal inhibitory concentration: 0.525 nM
For compound 3 the middle estimate is 1.9-fold (0.28 log units) above the measured one, and the stated range covers the measured number.
By their numbers in this assay, from the lowest: compound 2; then compound 3; then compound 1.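

In this assay, the gain at this position does not depend on chlorine: 2,4-difluorophenyl also improves on plain phenyl (a 12-fold lower number from compound 1 to compound 3 (1.09 log units; beyond the scatter)). The choice of atom still matters, as fluorine in place of chlorine gives back part of that gain (a 4.0-fold higher number from compound 2 to compound 3 (0.60 log units; beyond the scatter)). Nothing available explains this difference between the two atoms. The compounds shown leave open whether both ring substituents are needed, since every substituted ring here carries two identical halogens. They also leave open how methyl or methoxy groups would compare with these halogens on the same ring.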